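Compound 1 to compound 4: methoxy on the carbonyl carbon

This account rests on a few compounds, and the source may have more. Where it says the series, first, only, none or still open, it means among the compounds named here.

In a functional assay on MCF7 cells (Homo sapiens) (a lower number here means a stronger inhibitor, a higher number a weaker inhibitor), compound 1 `COc1cc(NC(C)CCCNC(=O)NCCCO)c2ncccc2c1` gives 31000 nM, within the scatter of compound 3 `COc1cc(NC(C)CCCNC(=O)N(CCO)CCO)c2ncccc2c1` at 36000 nM. Among the compounds with values here, compound 2 `COc1cc(NC(C)CCCNC(=O)NOCc2ccccc2)c2ncccc2c1` gives 9000 nM, the only clear departure from compound 1. Compound 4 `COC(=O)NCCCC(C)Nc1cc(OC)cc2cccnc12` carries methoxy in place of (3-hydroxypropyl)amino on a carbonyl carbon. Two measured steps change the same group of compound 1, and neither introduces methoxy. One is a 1.2-fold higher number from compound 1 to compound 3 (0.06 log units; within the scatter), and the other is a 3.4-fold lower number from compound 1 to compound 2 (0.54 log units; beyond the scatter). They give only a rough guide to size, so no step beyond the scatter is expected in this assay. The expected step is a 1.4-fold lower number from compound 1 to compound 4 (0.15 log units; within the scatter). The estimate for compound 4 is 22000 nM, with an expected range of 9000 nM to 50000 nM.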

Compound 4, half-maximal inhibitory concentration: > 100000 nM
Compound 4 ended at the assay's limit; the forecaster's own chance of this, stated with the estimate: 10%; middle value at least 4.5-fold (0.65 log units) away from the limit.
By their numbers in this assay, from the lowest: compound 2; then compounds 1 and 3 (each within the scatter of the next). At a limit, above all of these: compound 4.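

Compound 4 stands at a limit in this assay, not at a number: the limit of > 100000 nM in this assay, at which 1 of the 4 values shown sits.

The earlier groups on the carbonyl carbon all attach through nitrogen and all gave measured numbers, whereas methoxy, which attaches through oxygen, gives an at least 3.2-fold higher number from compound 1 to compound 4 (0.50 log units; beyond the scatter), an at least 2.7-fold higher number from compound 3 to compound 4 (0.44 log units; beyond the scatter) and an at least 11-fold higher number from compound 2 to compound 4 (1.04 log units; beyond the scatter). This single compound cannot separate the loss of that nitrogen from the loss of the hydroxypropyl chain.

Open, from the compounds shown here alone, is whether methylamino on the carbonyl carbon, or benzyloxy attached there directly, would give a measured number, which would separate these two changes.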